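This account rests on a few compounds, and the source may have more. Where it says the series, first, only, none or still open, it means among the compounds named here.

Measured compounds:
Compound 1, `COc1cc(C(=O)NC2CCN(C)CC2)ccc1Nc1ncc(Br)c(NC2CCCC2)n1`, gives 3500 nM in a functional assay on HeLa cells (Homo sapiens) for cytotoxicity, read by MTT assay, with a stated time of 48 h; on this read-out higher numbers stand for weaker inhibition and lower numbers for stronger inhibition.
Compound 2, `COc1cc(C(=O)NC2CCN(C)CC2)ccc1Nc1ncc(F)c(NC2CCCC2)n1`, gives 2200 nM in this assay.
Compound 3, `CCCNc1nc(Nc2ccc(N3CCN(C)CC3)cc2)ncc1F`, gives 14200 nM in this assay.

Among these three numbers, compound 1 holds the second highest. Compound 2 lies nearest to it, within the usual scatter, and compound 3 lies furthest, with a higher number that sits beyond the scatter. Going by the values given here, the only step between compounds that differ in one place is a 1.6-fold lower number from compound 1 to compound 2 (0.20 log units; within the scatter), which concerns a halogen exchange and says nothing about the change now at hand.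

Compound 4, `CN1CCC(NC(=O)c2ccc(Nc3ncc(Br)c(NC4CCCC4)n3)cc2)CC1`, has not been measured. It differs from compound 1 as follows: hydrogen in place of methoxy on an aromatic carbon. Among the compounds with values here, no measured pair in this set shows what removing a methoxy group from the shared core does, so there is no step to lean on, and no movement beyond the scatter is expected in this assay. Compound 4 is therefore expected to give about 3500 nM, with a range from 1500 nM to 8000 nM. This estimate means an expected step of no change at the digits printed from compound 1 to compound 4 (within the scatter).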

Compound 4, half-maximal inhibitory concentration: 900 nM
Beside the measured number, compound 4's estimate is 3.9-fold (0.59 log units) above it; measured number outside the range, below it.
By their numbers in this assay, from the lowest: compound 4; then compounds 2 and 1 (each within the scatter of the next); then compound 3.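

Going by these compounds alone, this is the first reading of the methoxy position on the shared core: in this assay, replacing the methoxy group with hydrogen gives a 3.9-fold lower number from compound 1 to compound 4 (0.59 log units; beyond the scatter), a modest step but one beyond the scatter. The methoxy group, ortho to a large group, is therefore not required for this cytotoxicity, since the number falls without it while the bromo group and the rest of compound 1 stay the same. Nothing available accounts for this fall in the number.

The compounds shown leave open whether a hydroxyl group, an ethoxy group or an amine on this aromatic carbon would give a number closer to that of the methoxy or the hydrogen compound. They also leave open whether the same change would give a similar step in the fluoro series of compound 2.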